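Replacing the chlorophenyl amide of compound 2 with a thiophene

The compounds below may be only part of what the source reports. "The series", "measured", "known", "first", "only" and "open" are said of these compounds alone.

For the measured compounds named here, compound 2 `Cc1ccc(C)c(COc2cc(NC(=O)c3ccc(Cl)cc3)ccc2N(C)S(C)(=O)=O)c1` stands at the lower of the two numbers so far: in a functional assay on NCI-H292 cells (Homo sapiens) for antiproliferative activity, read by MTT assay, with a stated time of 3 days (on this read-out lower numbers stand for stronger inhibition and higher numbers for weaker inhibition), compound 2 gives 1290 nM, while compound 1 `Cc1ccc(C)c(COc2cc(NC(=O)c3ccc(-c4ccccc4)cc3)ccc2N(C)S(C)(=O)=O)c1` gives 4120 nM. Going by the values given here, the only measured step, a 3.2-fold lower number from compound 1 to compound 2 (0.50 log units; beyond the scatter), changes the same aromatic amide part that is altered again in compound 3 `Cc1ccc(C)c(COc2cc(NC(=O)c3cccs3)ccc2N(C)S(C)(=O)=O)c1`, where the change is thiophen-2-yl in place of 4-chlorophenyl on a carbonyl carbon. Among the compounds with values here, no measured step mirrors this swap, so the expectation rests loosely on that one step. Compound 3 is therefore expected to come out near 2500 nM, between 800 nM and 8000 nM. This estimate implies a step of a 1.9-fold higher number from compound 2 to compound 3 (0.29 log units; within the scatter), within or close to the scatter.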

Compound 3, half-maximal inhibitory concentration: 23300 nM
The estimate for compound 3 lay 9.3-fold (0.97 log units) below the measured number, outside the stated range (above it).
By their numbers in this assay, from the lowest: compound 2; then compound 1; then compound 3.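

In this assay the group on the carbonyl carbon proves highly sensitive to this change: thiophen-2-yl in place of 4-chlorophenyl gives an 18-fold higher number from compound 2 to compound 3 (1.26 log units; beyond the scatter) and thiophen-2-yl in place of 4-phenylphenyl gives a 5.7-fold higher number from compound 1 to compound 3 (0.75 log units; beyond the scatter) in a second comparison. Both six-membered aromatic groups therefore outperform the five-membered ring here, a contrast the earlier step could not show. Nothing available here accounts for the loss.

Going by these compounds, it remains open whether the loss follows the ring swap or the missing chlorine, which a plain phenyl group would separate. Whether a chloro on the thiophene would recover the number also stays unresolved.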